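Aromatic methyl and cytotoxicity: compound 2 to compound 4

The compounds below may be only part of what the source reports. "The series", "measured", "known", "first", "only" and "open" are said of these compounds alone.

Compound 1 `O=C(N[C@@H]1COc2ccccc2NC1=S)c1n[nH]c(Cc2ccccc2)n1`, compound 2 `CN1C(=S)[C@@H](NC(=O)c2n[nH]c(Cc3ccccc3)n2)COc2ncccc21` and compound 3 `CN1C(=S)[C@H](NC(=O)c2n[nH]c(Cc3ccccc3)n2)COc2ncccc21` are the measured members of the series; compound 4 `Cc1ccc2c(n1)OC[C@H](NC(=O)c1n[nH]c(Cc3ccccc3)n1)C(=S)N2C` has not yet been measured. In an ADME assay on HT-29 cells (Homo sapiens) for cytotoxicity, read by luminescence and CellTiter-Glo, with a stated time of 10 h (on this read-out higher numbers stand for lower toxicity in this test and lower numbers for higher toxicity in this test), compound 1 gives > 50000 nM, which is a limit of the assay and not a number. In this assay compound 2 likewise gives only the limit > 50000 nM. In this assay compound 3 also stops at the limit > 50000 nM. Compound 2 therefore stands at the limit, with no number of its own. The step that the two limits leave unreadable from compound 2 to compound 3 cannot be read because of the limit of > 50000 nM in this assay, at which 3 of the 3 values shown sit, even though the fact that compounds 2 and 3 differ only in the configuration as drawn makes the pair the closest comparison available.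

Compound 4 differs from compound 2 by methyl in place of hydrogen on an aromatic carbon. Among the compounds with values here, no measured step carries a change of this kind, and the one step that was measured cannot be sized, so nothing here points to a move in this assay beyond the scatter. The expected step is a step that the limit leaves unreadable from compound 2 to compound 4, that is, no shift beyond the scatter. Compound 4 is thus estimated at 80000 nM in this assay, between 30000 nM and 250000 nM, and most probably reported again only as a limit.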

Compound 4, half-maximal cytotoxic concentration: > 50000 nM
Compound 4: only a limit was reported (the forecaster's own chance of this, stated with the estimate: 85%); the middle value is on the limit's open side.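

In this assay compound 4 gives > 50000 nM, which is a limit of the assay and not a number. The step from compound 2 to compound 4 therefore cannot be read: the limit of > 50000 nM in this assay, at which 4 of the 4 values shown sit.

The compounds shown leave open whether methyl in place of hydrogen on an aromatic carbon changes the half-maximal cytotoxic concentration at all.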